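The compounds below may be only part of what the source reports. "The series", "measured", "known", "first", "only" and "open" are said of these compounds alone.

compound 1 `CSCCSc1nc(NCc2ccc(-c3ccccn3)cc2)c2[nH]nc(C(C)C)c2n1`: 975 nM
compound 2 `CCC(CO)Sc1nc(NCc2ccc(-c3ccccn3)cc2)c2[nH]nc(C(C)C)c2n1`: 255 nM

In a functional assay on HT cells (Homo sapiens) for antiproliferative activity, read by fluorescence, with a stated time of 72 h (on this read-out higher numbers stand for weaker inhibition of growth and lower numbers for stronger inhibition of growth), compound 2 has the lower of the two numbers, at 255 nM, and its gap to compound 1 lies beyond the scatter. The next structure is compound 3 `CCC(O)CSc1nc(NCc2ccc(-c3ccccn3)cc2)c2[nH]nc(C(C)C)c2n1`, which has 2-hydroxybutyl in place of 1-(hydroxymethyl)propyl on a sulfur. The two substituents have the same atoms, joined differently. Among the measured compounds shown here, only one measured step bears on this change, the modest 3.8-fold lower number from compound 1 to compound 2 (0.58 log units; beyond the scatter), which also arose from a swap on that sulfur. For the measured compounds named here, it shows that this substituent can shift the number, but no measured pair tests moving the hydroxyl group within an isomeric chain. A smaller change is therefore expected in this assay, with a slight lean towards a higher number, and the expected step is a 1.4-fold higher number from compound 2 to compound 3 (0.14 log units; within the scatter). For compound 3 the estimated value is 350 nM, with an expected range of 130 nM to 950 nM.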

Compound 3, concentration for 50% growth inhibition: 273 nM
For compound 3 the middle estimate is 1.3-fold (0.11 log units) above the measured one; measured number inside the range.
By their numbers in this assay, from the lowest: compounds 2 and 3 (each within the scatter of the next); then compound 1.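

In this assay, exchanging 1-(hydroxymethyl)propyl for its isomer 2-hydroxybutyl on the sulfur gives a 1.1-fold higher number from compound 2 to compound 3 (0.03 log units; within the scatter) and so leaves the two chains indistinguishable, which means this shift of the hydroxyl within the chain does not register in these data. The second reading of the change, 1-hydroxypropyl in place of (methylsulfanyl)methyl on a saturated chain carbon bound to a sulfur, gives a 3.6-fold lower number from compound 1 to compound 3 (0.55 log units; beyond the scatter) and lies beyond the scatter, so both hydroxyl-bearing chains stand apart from the chain of compound 1. No supporting data bear on the origin of these numbers.

Going by these compounds, how an amine or a carboxylic acid in place of the hydroxyl would read stays open. The same holds for a longer chain carrying the hydroxyl on this sulfur.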